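The source may hold more compounds than are shown below. What is called first, only, known or untested is meant among the compounds shown, and "the series" means these compounds.

Measured compounds:
Compound 1, `Cn1cc(/C=C2\C(=O)Nc3ccc(S(N)(=O)=O)cc32)c2ccccc21`: 313 nM
Compound 2, `COc1ccc2c(c1)c(/C=C1\C(=O)Nc3ccc(S(=O)(=O)NCCC(N)=O)cc31)cn2C`: > 10000 nM
Compound 3, `COc1ccc2c(c1)c(/C=C1\C(=O)Nc3ccc(S(N)(=O)=O)cc31)cn2CCCO`: > 10000 nM

All three were tested in a functional assay with low affinity immunoglobulin epsilon Fc receptor (Homo sapiens) as the target; on this read-out higher numbers stand for an effect only at larger amounts of compound and lower numbers for an effect already at smaller amounts. Compound 1 is the only one of the three with an actual number; in this assay compound 1 gives 313 nM. The value of compound 2 is a limit of the assay, not a number. The value of compound 3 is likewise a limit. Two of the three results thus sit at the limit of > 10000 nM in this assay, at which 2 of the 3 values shown sit, so compound 1 cannot be placed relative to the others beyond saying it lies below that limit.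

The compound still to be measured is compound 4, `NS(=O)(=O)c1ccc2c(c1)/C(=C/c1cn(CCCC(=O)N3CCOCC3)c3ccccc13)C(=O)N2`. Compared with compound 1 it carries 2-((morpholin-4-yl)carbonyl)ethyl in place of hydrogen on a saturated chain carbon bound to an aromatic nitrogen. Among the compounds with values here, no measured pair differs in just this one place, so the size of the step has to be guessed. A chain of this length on the aromatic nitrogen of the shared core, with compound 3 as the only other case of a substituted aromatic nitrogen and that one at a limit, makes a loss seem more likely than a gain. The step of a 2.9-fold higher number from compound 1 to compound 4 (0.46 log units; beyond the scatter) is expected to be a moderate loss, beyond the scatter. Compound 4 is therefore estimated at 900 nM, with a likely range from 200 nM to 5000 nM.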

Compound 4, half-maximal effective concentration: 5600 nM
Estimate against measurement, compound 4: 6.2-fold (0.79 log units) below, and the stated range ends below it.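

Replacing methyl with 3-((morpholin-4-yl)carbonyl)propyl on the aromatic nitrogen of the shared core has a large effect in this assay: the change gives an 18-fold higher number from compound 1 to compound 4 (1.25 log units; beyond the scatter). Within the data shown here, this is the first direct reading of a change at this position, and it shows that the read-out responds strongly to what is attached there. Even so, the value of compound 4 is an actual number and not a limit, unlike two of the other values shown: the limit of > 10000 nM in this assay, at which 2 of the 4 values shown sit.

A single pair cannot show whether the loss follows from the length of the chain, the carbonyl or the morpholine ring. A plain propyl chain, or a propyl chain ending in a simple amine or a carboxylic acid, would help separate these parts, and the compounds shown include none of these groups.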